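A few compounds are considered here, and "the series" means these few. Any claim that something is new, unique, unknown or untested is made for them only; others in the source may bear on it.

Measured in a functional assay on MCF7 cells (Homo sapiens) for cytotoxicity, in the presence of a further agent that is not named here; a higher number here means that more compound is needed for the effect, a lower number that less compound is needed:

Compound 1 `CCCCCCCO[C@@H]1[C@@H](O)[C@@H](OCc2ccccc2)O[C@H](CC(C)C)[C@H]1OC`: 7 ug/mL
Compound 2 `CCCCCCCO[C@@H]1[C@@H](O)[C@@H](OCc2ccccc2)O[C@@H]2CO[C@@H](c3ccc(OC)cc3)O[C@@H]12`: 2.5 ug/mL
Compound 3 `CCCCCCCO[C@@H]1[C@@H](OCc2ccccc2)[C@@H](OCc2ccccc2)O[C@H](CO)[C@H]1OCc1ccc(OC)cc1`: 3 ug/mL

Compound 3 gives 3 ug/mL, and compound 2 at 2.5 ug/mL lies within the usual scatter of it, so these two values cannot be ranked. Compound 1 at 7 ug/mL stands apart from compound 3, with a number beyond the scatter: more of compound 1 is needed for the effect.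

Compound 4 `CCCCCCCO[C@@H]1[C@@H](OCc2ccccc2)[C@@H](OCc2ccccc2)O[C@H](C=O)[C@H]1OCc1ccc(OC)cc1` keeps the frame of compound 3 with one change: formyl in place of hydroxymethyl on a saturated ring carbon, next to the ring oxygen (formyl in place of hydroxymethyl on a saturated ring carbon).

For the measured compounds named here, no two measured compounds differ in only one place, so the data offer no direct guide to this change, neither in size nor in direction. The best anchor is compound 3 itself at 3 ug/mL, and a small set of structurally varied compounds gives little reason to expect a large departure from it. The expected result is a 1.2-fold lower number from compound 3 to compound 4 (0.08 log units; within the scatter), which would be no change beyond the scatter, and its direction is only a weak guess. The estimated value for compound 4 in this assay is 2.5 ug/mL, with an expected range from 1 ug/mL to 6 ug/mL.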

Compound 4, half-maximal effective concentration: 4 ug/mL
Compound 4: middle estimate off by 1.6-fold (0.20 log units), on the low side; the measured number falls inside the stated range.
By their numbers in this assay, from the lowest: compounds 2, 3, 4 and 1 (each within the scatter of the next, the first and the last beyond it).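

In this assay, for the compounds shown here, formyl in place of hydroxymethyl on the saturated ring carbon next to the ring oxygen gives a 1.3-fold higher number from compound 3 to compound 4 (0.12 log units; within the scatter) and so provides the first direct reading of a single change in this set, one that cannot be told apart from no change at all. At this position, then, the hydrogen-bond donor of hydroxymethyl, which formyl does not carry, can be given up with no shift beyond the scatter, at least for this one pair on this frame. Nothing measured here bears on why the two compounds read alike.

From the compounds shown here alone, what remains open is whether this position tolerates change more widely, since two closely matched groups of equal size say little about a carboxylic acid, an aminomethyl group or a longer alkyl chain in the same place. Going by these compounds, it is also open whether the same exchange would read alike on another frame, and whether a different result would appear without the further agent present in this assay.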